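Urea-to-amide switch in a pyrazole series: cytotoxicity notes

The source may report more compounds than this note shows. Statements on the series, on what has been measured and on what is new or still open speak of the compounds shown alone.

Measured compounds:
compound 1 `COc1cc(-c2nn(-c3cccc(NC(=O)Nc4ccc(Cl)c(Cl)c4)c3)cc2-c2ccncc2)ccc1Cl` — > 50000 nM
compound 2 `COc1cc(-c2nn(-c3cccc(NC(=O)Nc4cccc(C(F)(F)F)c4)c3)cc2-c2ccncc2)ccc1Cl` — > 50000 nM

Compound 1 is read in a functional assay on A549 cells (Homo sapiens) for inhibition, read by sulforhodamine B assay, with a stated time of 48 h (on this read-out higher numbers stand for lower toxicity in this test and lower numbers for higher toxicity in this test), only as a limit of the assay, > 50000 nM. Compound 2 likewise reaches only the limit of this assay, > 50000 nM. Among the measured compounds shown here, the one step between measured compounds, a step that the two limits leave unreadable from compound 1 to compound 2, cannot be sized because of the limit of > 50000 nM in this assay, at which 2 of the 2 values shown sit.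

Compound 3 `COc1cc(-c2nn(-c3cccc(NC(=O)c4ccc(Cl)c(C(F)(F)F)c4)c3)cc2-c2ccncc2)ccc1Cl` differs from compound 2 in that (4-chloro-3-(trifluoromethyl)phenyl in place of (3-(trifluoromethyl)phenyl)amino on a carbonyl carbon); the urea linkage becomes a simple amide, and 4-chloro-3-(trifluoromethyl)phenyl replaces (3-(trifluoromethyl)phenyl)amino. For the measured compounds named here, no measured step bears on this change beyond the two limits, which give no direction. Compound 3 is therefore expected to sit at or near the same limit of this assay, a step that the limit leaves unreadable from compound 2 to compound 3 being the estimate. The expected value for compound 3 is 70000 nM, within a range from 20000 nM to 200000 nM, most likely again reported only as a limit.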

Compound 3, concentration lethal to 50% of the cells: > 32500 nM
Compound 3 ended at the assay's limit; the forecaster's own chance of this, stated with the estimate: 75%; the middle value does not contradict the limit.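

Among the compounds shown here, no step among compound 1, compound 2 and compound 3 can be read in this assay, as all three values are limits of the assay. Still open, going by these compounds, is whether the change from urea to amide alters the lethal concentration in this assay, and by how much.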